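Working notes: a methyl step from compound 1

The source may hold more compounds than are shown below. What is called first, only, known or untested is meant among the compounds shown, and "the series" means these compounds.

Measured in a functional assay on CWR22R cells (Homo sapiens) for antiproliferative activity, read by CCK-8 assay, with a stated time of 6 days; on this read-out lower numbers stand for stronger inhibition and higher numbers for weaker inhibition:
- compound 1 `CCN(c1cccc(-c2ccccc2)c1)c1ccc(C#N)c(Cl)c1`: "not determined" (no result reported)
- compound 2 `N#Cc1ccc(N2CCCc3c(-c4cccnc4)cccc32)cc1C(F)(F)F`: 12300 nM
- compound 3 `CCN(c1ccc(C#N)c(Cl)c1)c1cc(-c2cnc3ccccc3c2)ccc1C`: "not determined" (no result reported)

Not yet measured: compound 4 `CCN(c1ccc(C#N)c(Cl)c1)c1cc(-c2ccccc2)ccc1C`.

In this assay compound 1 has no single number, only "not determined" (no result reported), and compound 3 likewise stands at "not determined" (no result reported). The step under study is methyl in place of hydrogen on an aromatic carbon, which is methyl in place of hydrogen on an aromatic carbon. For the measured compounds named here, no measured step shows what such a change does here. The expectation is therefore for no shift beyond the usual scatter in this assay, in either direction. Going by the values given here, the only numeric anchor is compound 2 at 12300 nM, although it does not share the core of compound 1. For compound 4 the expected value is 8000 nM, with an estimated range of 1500 nM to 30000 nM.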

Compound 4, half-maximal inhibitory concentration: > 30000 nM
Compound 4 was reported as a limit (the forecaster's own chance of this, stated with the estimate: 20%); at least 3.7-fold (0.57 log units) between middle value and limit.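

In this assay compound 4 gives > 30000 nM, which is a limit and not a number. For the compounds shown here, compound 1 stands at "not determined" (no result reported), and no step from compound 1 to compound 4 can be read. The compounds shown leave open what methyl in place of hydrogen on this aromatic carbon does to antiproliferative potency.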